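The compounds below may be only part of what the source reports. "The series", "measured", "known", "first", "only" and "open" are said of these compounds alone.

Measured compounds:
- compound 1, `Cc1cc(NCc2ccccn2)n2ncc(Br)c2n1`: 89300 nM
- compound 2, `Cc1cc(NCc2nccn2C)n2nc(C)cc2n1`: 182000 nM

In a physicochemical assay for solubility, read by HPLC, using the shake flask method, measured as kinetic solubility, with a stated time of 2 h, at pH 7.4 (on this read-out higher numbers stand for higher solubility and lower numbers for lower solubility), compound 1 gives 89300 nM and stands as the lower of the two numbers; in this assay compound 2 gives 182000 nM, and the gap between the two values lies beyond the scatter. No single-point change between measured compounds is available, so the effect of any one alteration on the read-out is not yet known from the numbers themselves.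

Compound 3, `Cc1cc(NCc2ccccn2)n2ncc(-c3cncnc3)c2n1`, is the next compound to be measured in this assay. It differs from compound 1 by pyrimidin-5-yl in place of bromo on an aromatic carbon. With the two compounds above as the only reference, a small step is expected for compound 3, with the estimate a 1.3-fold higher number from compound 1 to compound 3 (0.13 log units; within the scatter) from compound 1 to compound 3 leaning upward but close to the scatter. Compound 3 is estimated at 120000 nM, within 40000 nM to 320000 nM.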

Compound 3, solubility: 111000 nM
Estimate against measurement, compound 3: 1.1-fold (0.03 log units) above; low and high end bracket the measured number.
By their numbers in this assay, from the lowest: compounds 1, 3 and 2 (each within the scatter of the next, the first and the last beyond it).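

In this assay, for the compounds shown here, the first single-point comparison, pyrimidin-5-yl in place of bromo on an aromatic carbon of the five-membered aromatic ring gives a 1.2-fold higher number from compound 1 to compound 3 (0.09 log units; within the scatter). At this position, the change from one heavy atom to six heavy atoms, including a six-membered aromatic ring, therefore leaves the two compounds unseparated on this read-out. No measured evidence on hand bears on this outcome.

Still open, as far as these compounds go, is whether an amine, a carboxylic acid or a longer chain at this same position would give a step beyond the scatter. Also open, from the compounds shown here alone, is whether pyrimidin-5-yl in place of bromo would give a similar step with the 1-methylimidazol-2-ylmethyl-type amine side chain of compound 2 or other groups elsewhere on the shared core.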